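The source may report more compounds than this note shows. Statements on the series, on what has been measured and on what is new or still open speak of the compounds shown alone.

Measured compounds:
compound 1 `O=C(NO)c1ccc(NCc2nc(-c3ccco3)nn2-c2ccccc2)cc1` gives 59.9%
compound 2 `O=C(NO)c1ccc(NCc2nc(-c3ccccc3)nn2-c2ccc(Br)cc2)cc1` gives 65.9%
compound 3 `Nc1ccccc1NC(=O)c1ccc(NCc2nc(-c3ccccc3)nn2-c2ccccc2)cc1` gives 5%

In an assay on Sf9 cells for inhibition of protein deacetylase HDAC6 (Homo sapiens), read by fluorescence, with a stated time of 40 min, tested at 100 nM (a lower number here means less inhibition, a higher number more inhibition at the concentration tested (going by the name of the read-out)), compound 1 stands second highest of the three numbers. Its nearest neighbour is compound 2, whose value lies within the usual scatter of that of compound 1; the furthest is compound 3, which falls far below, beyond the scatter. Compound 4 `O=C(NO)c1ccc(NCc2nc(-c3ccc(F)cc3)nn2-c2ccccc2)cc1` differs from compound 1 by 4-fluorophenyl in place of furan-2-yl on an aromatic carbon. Going by the values given here, no measured pair shows this change, so its effect in this assay cannot be read off from the data. Compound 1 and compound 2 carry different groups in this region yet give values within the scatter of each other, which suggests modest sensitivity here. The step of a number 2.1 percentage points higher from compound 1 to compound 4 (within the scatter) is therefore expected to stay within the scatter, with no clear direction. Compound 4 is estimated to give 62%, in a range from 45% to 78%.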

Compound 4, a percentage reported as inhibition, at one concentration (the size of the read-out at that concentration, not a potency): 70.9%
Beside the measured number, compound 4's estimate is 8.9 percentage points below it; the measured number falls inside the stated range.
By their numbers in this assay, from the lowest: compound 3; then compounds 1, 2 and 4 (each within the scatter of the next, the first and the last beyond it).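

In this assay, going by these compounds alone, 4-fluorophenyl in place of furan-2-yl on the aromatic carbon gives a number 11 percentage points higher from compound 1 to compound 4 (beyond the scatter) as the first readable step at this position. It shows that the position responds to this change, though modestly, and that a six-membered aromatic ring of carbon only is accepted there in place of the five-membered ring. Nothing available explains the step.

The compounds shown leave open what plain phenyl would give at this position, which would separate the ring from its fluorine. They also leave open how an amine or a carboxylic acid on that ring would fare.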